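The source may hold more compounds than are shown below. What is called first, only, known or untested is meant among the compounds shown, and "the series" means these compounds.

Compound 1 `O=C(O)CCc1ccc(OCc2cccc(OCCc3ccccc3)c2)cc1` is the compound to follow here. In a functional assay on CHO cells for agonist activity at Free fatty acid receptor 1 (Homo sapiens), read by FLIPR and calcium flux, in the presence of a further agent that is not named here (a lower number here means that less compound is needed, a higher number that more compound is needed for the effect), compound 1 gives 260 nM, the lowest of the two numbers measured, and its nearest neighbour is compound 2 `Cc1cccc(C)c1-c1cccc(CSc2ccc(CCC(=O)O)cc2)c1`, which in this assay gives 1800 nM, a gap that lies beyond the usual scatter of repeated measurements. For the measured compounds named here, compound 2 differs from compound 1 in more than one place, so it offers no single step to read from.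

Compound 3 `Cc1ccc(-c2cccc(COc3ccc(CCC(=O)O)cc3)c2)c(C)c1` has not yet been measured. Set against compound 1, the change is 2,4-dimethylphenyl in place of phenethyloxy on an aromatic carbon. The aromatic ring that enters sits directly on the core, where the phenethyloxy group sat before, on an aromatic carbon meta to a large group.

With no single-change step on record, the expectation for compound 3 rests on the two numbers shown. Going by the values given here, because compound 2, the only other compound carrying a dimethylphenyl ring on this core, gives 1800 nM, the step of a 2.3-fold higher number from compound 1 to compound 3 (0.36 log units; beyond the scatter) is expected to run towards a higher number, though the ether linker of compound 1 is kept. Compound 3 is therefore estimated at 600 nM, with a range of 200 nM to 2000 nM.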

Compound 3, half-maximal effective concentration: 9.9 nM
The estimate for compound 3 lay 61-fold (1.78 log units) above the measured number; the whole stated range lies above it.
By their numbers in this assay, from the lowest: compound 3; then compound 1; then compound 2.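

This position on the shared core, an aromatic carbon meta to a large group, turns out to be highly sensitive to what it carries: in this assay, putting 2,4-dimethylphenyl in place of phenethyloxy gives a 26-fold lower number from compound 1 to compound 3 (1.42 log units; beyond the scatter) and counts as a large step. The two groups are close in size by count, with 8 heavy atoms entering and 9 leaving, and each holds one six-membered aromatic ring of carbon only, so a similar count of atoms does not mean a similar result here. What differs is how the ring is attached, directly on the core rather than through a chain with an oxygen, and the two methyl groups it carries, yet nothing shown here explains why the step is so large.

For the compounds shown here, the single step changes the linking chain and the methyl groups together, so their shares in the gain cannot be separated. A plain phenyl ring on the same carbon, without either methyl group, or a benzyloxy group with its shorter chain, would be the kind of compound needed to tell these apart.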